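The compounds below may be only part of what the source reports. "The series", "measured", "known", "first", "only" and "open" are said of these compounds alone.

Compound 1 `Cc1ccc(N2C(=O)CS/C2=N/N=C/c2c[nH]c3ccc(Br)cc23)cc1`: 96600 nM
Compound 2 `O=C1CS/C(=N/N=C/c2c[nH]c3ccc(Br)cc23)N1c1cccc2ccccc12`: > 100000 nM (a limit of the assay)

Going by the values given here, in a functional assay on NCI-H460 cells (Homo sapiens) for inhibition, read by spectrophotometry and sulforhodamine B assay, with a stated time of 48 h (on this read-out higher numbers stand for weaker inhibition of growth and lower numbers for stronger inhibition of growth), compound 1 gives 96600 nM, the only true number so far. Compound 2 gives > 100000 nM, which is a limit and not a number. Compound 3 `Cc1ccc(N2C(=O)CS/C2=N/N=C/c2c[nH]c3ccccc23)cc1` differs from compound 1 by one change, hydrogen in place of bromo on an aromatic carbon. Among the compounds with values here, no measured step bears on this change, so no shift beyond the scatter is expected in this assay, in either direction. Compound 3 is estimated at 85000 nM, with an expected range of 30000 nM to 100000 nM.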

Compound 3, concentration for 50% growth inhibition: > 100000 nM
Compound 3 was reported as a limit; the forecaster's own chance of this, stated with the estimate: 40%; middle value at least 1.1-fold (0.07 log units) away from the limit.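

In this assay, hydrogen in place of bromo on an aromatic carbon gives an at least 1.0-fold higher number from compound 1 to compound 3 (0.01 log units; that floor lies within the scatter). The value of compound 3 is a limit and not a number, so that floor is all that can be read. At this position, hydrogen therefore shows no stronger inhibition of growth than bromo, but the true size of the step stays unknown because the read-out stops at the limit: the limit of > 100000 nM in this assay, at which 2 of the 3 values shown sit.

As far as these compounds go, whether an amine, a methoxy group or a carboxylic acid on this same aromatic carbon would give a true number stays open. From the compounds shown here alone, whether chloro would match bromo also stays open.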